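The source may report more compounds than this note shows. Statements on the series, on what has been measured and on what is new or still open speak of the compounds shown alone.

Compound 1 `O=S(=O)(c1ccc(F)c(Cl)c1)c1cnc2c(F)cccc2c1-c1ccc(F)cc1` gives the lowest number of the three measured in an ADME assay on microsomes from liver (Homo sapiens) for metabolic stability, tested at 2.5 uM (a higher number here means faster removal of the compound, a lower number slower removal), at 0.19 mL/min. Compound 2 `Cc1ccc(S(=O)(=O)c2cnc3c(F)cccc3c2-c2ccc(F)cc2)cc1F` gives 2.75 mL/min in this assay, and compound 3 `O=S(=O)(c1cc(Cl)cc(Cl)c1)c1cnc2c(F)cccc2c1-c1ccc(F)cc1` gives 1.01 mL/min. Both measured steps from compound 1 change the aryl on the sulfonyl sulfur: a 14-fold higher number from compound 1 to compound 2 (1.16 log units; beyond the scatter) and a 5.3-fold higher number from compound 1 to compound 3 (0.73 log units; beyond the scatter); between the other two, a 2.7-fold lower number from compound 2 to compound 3 (0.44 log units; beyond the scatter). Compound 4 `O=S(=O)(c1ccc(F)c(Cl)c1)c1cnc2c(F)cccc2c1-c1ccc(Cl)cc1` differs from compound 1 at a different place: chloro in place of fluoro on an aromatic carbon. Going by the values given here, no measured step touches this place, so the steps at the sulfonyl aryl give no direct guide, and the expected step in this assay is a 1.6-fold higher number from compound 1 to compound 4 (0.20 log units; within the scatter), close to the scatter. Compound 4 is therefore estimated at 0.3 mL/min in this assay, with a range from 0.12 mL/min to 0.8 mL/min.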

Compound 4, intrinsic clearance in a liver preparation (reported as CLH), per the amount of preparation that the assay uses: 0.01 mL/min
Estimate against measurement, compound 4: 30-fold (1.48 log units) above; measured number outside the range, below it.
By their numbers in this assay, from the lowest: compound 4; then compound 1; then compound 3; then compound 2.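

The change from 4-fluorophenyl to 4-chlorophenyl, para to a large group, is a single-atom swap that still gives a large step in this assay: a 19-fold lower number from compound 1 to compound 4 (1.28 log units; beyond the scatter). This place therefore moves the number strongly downward, whereas both measured changes from compound 1 at the sulfonyl aryl raised it. No measurement shown accounts for the drop. Still open, from the compounds shown here alone, is whether the same swap gives a similar step with the other sulfonyl aryl groups, and what a methoxy or a nitrile at this place would give.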